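Aryl exchange on the dimethylaminopropyl analogue

This account rests on a few compounds, and the source may have more. Where it says the series, first, only, none or still open, it means among the compounds named here.

Measured so far:
compound 1 `Cc1nn(C)c2c1C(c1cccc(Cl)c1)=NCCN2N=O`, in a functional assay on the whole organism for positive allosteric modulation, with Rattus norvegicus as the target (on this read-out lower numbers stand for an effect already at smaller amounts and higher numbers for an effect only at larger amounts of compound), compound 1 gives 1.25 mg/kg.
compound 2 `Cc1nn(C)c2c1C(c1cccc(Cl)c1)=NCCN2CCCN(C)C`, compound 2 reaches only the assay limit, > 10 mg/kg.

Compound 2 therefore stands at the upper edge of the numbers shown, with no exact value. Among the compounds with values here, the single measured step is an at least 8.0-fold higher number from compound 1 to compound 2 (0.90 log units; beyond the scatter), and it concerns the group on the ring nitrogen, not the aryl group; it ends in the limit described by the limit of > 10 mg/kg in this assay, at which 1 of the 2 values shown sits.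

Compound 3 `Cc1ccc(C2=NCCN(CCCN(C)C)c3c2c(C)nn3C)cc1` keeps the side chain of compound 2 and differs only by 4-methylphenyl in place of 3-chlorophenyl on a carbon with a double bond to nitrogen. Within the data shown here, no measured step touches this position, so there is no basis for expecting a change beyond the scatter; the expected step is a number no higher from compound 2 to compound 3 (the limit leaves the size open), and compound 3 is estimated to stay at the limit, around 10 mg/kg, with a range from 3 mg/kg to 30 mg/kg.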

Compound 3, minimum effective dose: > 10 mg/kg
Compound 3 gave a limit, no number; the forecaster's own chance of this, stated with the estimate: 65%; the middle value lies on the limit itself.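

No step can be read between compound 2 and compound 3, because both values are limits: the limit of > 10 mg/kg in this assay, at which 2 of the 3 values shown sit. The compounds shown leave open whether 4-methylphenyl and 3-chlorophenyl differ at all when the 3-(dimethylamino)propyl group is on the shared core.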